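The source may hold more compounds than are shown below. What is called first, only, known or untested is meant among the compounds shown, and "the series" means these compounds.

Compound 1 `COc1ccc(OC)c(/C=N/NC(=O)Nc2ccc(Oc3ccnc(-c4nncn4CCN(C)C)c3)c(F)c2)c1` gives 1950 nM in a functional assay on A549 cells (Homo sapiens) for cytotoxicity, read by MTT assay, with a stated time of 72 h; on this read-out lower numbers stand for stronger inhibition and higher numbers for weaker inhibition. Compound 2 `CN(C)CCn1cnnc1-c1cc(Oc2ccc(NC(=O)N/N=C/c3cccc(O)c3)cc2F)ccn1` reaches only a limit of the assay, > 100000 nM. Compound 3 `CN(C)CCn1cnnc1-c1cc(Oc2ccc(NC(=O)N/N=C/c3ccc(O)c(O)c3)cc2F)ccn1` also sits at a limit, > 100000 nM.

On the numbers shown, compound 3 therefore stands at a limit rather than at a number, as one further value does (the limit of > 100000 nM in this assay, at which 2 of the 3 values shown sit). Compound 4 `CN(C)CCn1cnnc1-c1cc(Oc2ccc(NC(=O)N/N=C/c3ccc(O)cc3)cc2F)ccn1` differs from compound 3 by hydrogen in place of hydroxy on an aromatic carbon. Going by the values given here, the steps that bear on this are an at least 51-fold higher number from compound 1 to compound 2 (1.70 log units; beyond the scatter) and an at least 51-fold higher number from compound 1 to compound 3 (1.70 log units; beyond the scatter), both large and in the same direction, whereas a step that the two limits leave unreadable from compound 2 to compound 3. Because both hydroxyphenyl compounds sit at the limit (the limit of > 100000 nM in this assay, at which 2 of the 3 values shown sit), compound 4 is expected to stay near that limit, and a number no higher from compound 3 to compound 4 (the limit leaves the size open) is expected to be small or unreadable. Compound 4 is thus estimated at 100000 nM, within 20000 nM to 300000 nM.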

Compound 4, half-maximal inhibitory concentration: 3560 nM
Compound 4: the middle estimate sits 28-fold (1.45 log units) above what was measured, and the stated range ends above it.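

Hydrogen in place of the hydroxy that stands ortho to a hydroxy group gives an at least 28-fold lower number from compound 3 to compound 4 (1.44 log units; beyond the scatter), so this place on the ring matters. The single hydroxy matters too, with an at least 28-fold lower number from compound 2 to compound 4 (1.44 log units; beyond the scatter) on going to 4-hydroxyphenyl. That group and 2,5-dimethoxyphenyl read alike, with a 1.8-fold higher number from compound 1 to compound 4 (0.26 log units; within the scatter), so a hydroxy on this ring does not by itself end the activity.

The step between compound 2 and compound 3 cannot be read, as both values are limits of the assay. Going by these compounds, whether 4-methoxyphenyl, 4-aminophenyl or unsubstituted phenyl would behave like 4-hydroxyphenyl stays open.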